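Methoxy to Nitro on the Aromatic Ring: A Forecast

A few compounds are considered here, and "the series" means these few. Any claim that something is new, unique, unknown or untested is made for them only; others in the source may bear on it.

Measured so far:
Compound 1 `COc1ccc(C2=NO[C@]3(C2)C(=O)O[C@@H]2[C@H]3CC[C@H](C)[C@]3(O)C=CC(=O)[C@@]23C)cc1`: in a functional assay on PC-3 cells (Homo sapiens) for cytotoxicity, read by sulforhodamine B assay, with a stated time of 48 h (a lower number here means a stronger inhibitor, a higher number a weaker inhibitor), compound 1 gives 35000 nM
Compound 2 `C[C@H]1CC[C@@H]2[C@@H](OC(=O)[C@]23CC(c2ccccc2Br)=NO3)[C@]2(C)C(=O)C=C[C@@]12O`: in this assay compound 2 gives 51000 nM
Compound 3 `C[C@H]1CC[C@@H]2[C@@H](OC(=O)[C@]23CC(c2ccccc2)=NO3)[C@]2(C)C(=O)C=C[C@@]12O`: in this assay compound 3 gives 46000 nM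

Compound 1 shows the lowest of the three numbers, but the gaps are small: a 1.3-fold higher number from compound 1 to compound 3 (0.12 log units; within the scatter) and a 1.5-fold higher number from compound 1 to compound 2 (0.16 log units; within the scatter). The three compounds therefore cannot be told apart on these data, and none of them can be called the most or least potent.

Compound 4 `C[C@H]1CC[C@@H]2[C@@H](OC(=O)[C@]23CC(c2ccc([N+](=O)[O-])cc2)=NO3)[C@]2(C)C(=O)C=C[C@@]12O` keeps the shared core of compound 1 and changes only the group on the aromatic ring: nitro in place of methoxy on an aromatic carbon.

Among the measured compounds shown here, two measured steps bear on this. Removing the methoxy altogether, a 1.3-fold higher number from compound 1 to compound 3 (0.12 log units; within the scatter), changed nothing beyond the scatter, and replacing the 4-methoxyphenyl with 2-bromophenyl, a 1.5-fold higher number from compound 1 to compound 2 (0.16 log units; within the scatter), likewise stayed within it; the remaining pair, a 1.1-fold lower number from compound 2 to compound 3 (0.04 log units; within the scatter), was flat as well. Every change on this ring so far has left the read-out of this assay essentially where it was, so no step beyond the scatter is expected for the nitro group either, in either direction.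

Compound 4 is therefore estimated to give 40000 nM, within a range of 18000 nM to 90000 nM. That estimate means an expected step of a 1.1-fold higher number from compound 1 to compound 4 (0.06 log units; within the scatter).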

Compound 4, half-maximal inhibitory concentration: 12000 nM
Beside the measured number, compound 4's estimate is 3.3-fold (0.52 log units) above it; the whole stated range lies above it.
By their numbers in this assay, from the lowest: compound 4; then compounds 1, 3 and 2 (each within the scatter of the next).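

In this assay, among the compounds shown here, this aromatic ring is not as indifferent as the earlier compounds made it appear: the 4-nitrophenyl group gives the first change on it that lies beyond the scatter, a modest 2.9-fold lower number from compound 1 to compound 4 (0.46 log units; beyond the scatter) when nitro replaces methoxy. The same holds when nitro replaces hydrogen, with a 3.8-fold lower number from compound 3 to compound 4 (0.58 log units; beyond the scatter) and when 4-nitrophenyl replaces 2-bromophenyl, with a 4.3-fold lower number from compound 2 to compound 4 (0.63 log units; beyond the scatter) so compound 4 is the most potent of the four, while compounds 1, 2 and 3 stay within the scatter of one another. The aromatic carbon para to a large group can therefore affect this read-out, at least with nitro there, although nothing shown here accounts for the step.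

The compounds shown leave open whether other groups at this place, such as an amine, a nitrile or a carboxylic acid, would lower the number as nitro does or leave it near the value with methoxy. They also leave open whether a 2-nitrophenyl group would match the 4-nitrophenyl group, so the result cannot yet be separated from that one placement of nitro.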